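A few compounds are considered here, and "the series" means these few. Any claim that something is new, unique, unknown or untested is made for them only; others in the source may bear on it.

Among the measured compounds shown here, the three compounds measured so far share one core and differ in the groups attached to it. Compound 1 `COc1ccc(C2SC(C)C(=O)Nc3c2c(C)nn3-c2ccccc2C)c(OC)c1` carries a 2-methylphenyl on an aromatic nitrogen, and in an assay on isolated protein for agonist activity at Bile acid receptor (Homo sapiens), read by AlphaScreen, with a stated time of 30 min (on this read-out lower numbers stand for smaller maximal responses and higher numbers for larger maximal responses), compound 1 gives 63%. Compound 3 `Cc1nn(-c2ccccc2C(F)(F)F)c2c1C(c1ccc(Oc3ccccc3)cc1)SC(C)C(=O)N2`, which carries a trifluoromethyl-bearing phenyl at that same nitrogen, gives 50% in this assay. Compound 2 `Cc1ccc(-n2nc(C)c3c2NC(=O)[C@H](C)S[C@@H]3c2ccc(Oc3ccccc3)cc2)cc1`, with a 4-methylphenyl at that nitrogen, gives 11% in this assay; this is the lowest of the three numbers, compound 3 stands nearest and compound 1 furthest, and both gaps lie beyond the usual scatter.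

Compound 4 `Cc1ccccc1-n1nc(C)c2c1NC(=O)[C@H](C)S[C@@H]2c1ccc(Oc2ccccc2)cc1` has not yet been measured. It keeps every atom of compound 2 but joins them differently: 2-methylphenyl in place of 4-methylphenyl on an aromatic nitrogen. For the measured compounds named here, no measured pair in this set differs in exactly this way, so the size of the step cannot be read off directly. Still, an upward step in this assay that clears the scatter is expected, because compound 1 gives 63% in this assay while bearing 2-methylphenyl on that same aromatic nitrogen, although compound 1 also differs from compound 4 elsewhere. For compound 4 the expected largest response is 40%, with a range from 15% to 65%. The estimated step would then be a number 29 percentage points higher from compound 2 to compound 4 (beyond the scatter).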

Compound 4, largest response reached (reported as efficacy), in percent of the reference or control that the assay uses: 118%
Compound 4: middle estimate off by 78 percentage points, on the low side; measured number outside the range, above it.
By their numbers in this assay, from the lowest: compound 2; then compound 3; then compound 1; then compound 4.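

Among the compounds shown here, this is the first pair in the set that differs in one place only, and it shows that the site of the methyl group on this phenyl ring has a very large effect on the response. In this assay, 2-methylphenyl in place of 4-methylphenyl on the aromatic nitrogen gives a number 107 percentage points higher from compound 2 to compound 4 (beyond the scatter), even though the rest of the molecule stays the same. The leaving and entering groups match in every count available, with the same heavy atoms, one aromatic ring each, no hydrogen-bond donors or acceptors and no net charge, so these counts do not separate them, and nothing at hand accounts for the size of the step.

The compounds shown leave open whether the response depends on the methyl group itself or would also be reached with an unsubstituted phenyl, a 2-ethylphenyl or a 2-methoxyphenyl on that nitrogen. For the compounds shown here, they also leave open whether the same change would give a step of similar size with a different group in place of the phenoxy-bearing phenyl, since no such matched pair is available.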